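Ring-nitrogen acylation in a nitrophenyl dihydropyrimidine series

A few compounds are considered here, and "the series" means these few. Any claim that something is new, unique, unknown or untested is made for them only; others in the source may bear on it.

Compound 1 `CC1=C(C(=O)OC(C)C)C(c2cccc([N+](=O)[O-])c2)NC(=S)N1` carries a free hydrogen on both ring nitrogens and in an assay on HEK293 cells for antagonist activity at Voltage-dependent L-type calcium channel subunit alpha-1D (Rattus norvegicus), read by FLIPR (a higher number here means a weaker inhibitor, a lower number a stronger inhibitor), compound 1 gives 15800 nM. Compound 3 `COC(=O)N1C(=S)NC(C)=C(C(=O)OC(C)C)C1c1cccc([N+](=O)[O-])c1` is the same core with one substitution: methoxycarbonyl in place of hydrogen on an amide-type nitrogen in a ring. In this assay compound 3 gives 550 nM, so the step of a 29-fold lower number from compound 1 to compound 3 (1.46 log units; beyond the scatter) is the largest single change seen among the measured compounds.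

Compound 2 `COC(=O)N1C(=O)NC(C)=C(C(=O)OC(C)C)C1c1cccc([N+](=O)[O-])c1` shares the substitution pattern of compound 3 but on a different core; the difference between the two cores is not broken down here. In this assay compound 2 gives 2960 nM, which places it between compound 1 and compound 3.

Compound 4 `COC(=O)N1C(=O)N(C(=O)OC)C(c2cccc([N+](=O)[O-])c2)C(C(=O)OC(C)C)=C1C` is not yet measured. It differs from compound 2 by methoxycarbonyl in place of hydrogen on an amide-type nitrogen in a ring. This is the same kind of change as that from compound 1 to compound 3, but not the same: in compound 3 the entering group sits next to the ring atom that bears a 3-nitrophenyl group, whereas in compound 4 it sits next to the ring atom that bears a methyl group, and in compound 4 no ring nitrogen is left with a hydrogen. Because the earlier step of a 29-fold lower number from compound 1 to compound 3 (1.46 log units; beyond the scatter) was made at the other nitrogen and on a different core, it is taken only as a loose guide, and a smaller step is expected for compound 4, a 2.5-fold lower number from compound 2 to compound 4 (0.39 log units; beyond the scatter). Compound 4 is therefore estimated at 1200 nM in this assay, with a likely range from 300 nM to 5000 nM.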

Compound 4, half-maximal inhibitory concentration: 5880 nM
For compound 4 the middle estimate is 4.9-fold (0.69 log units) below the measured one; measured number above the stated range.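

Carrying methoxycarbonyl onto an amide-type nitrogen in a ring does not give a step that transfers between cores in this assay: the same change on two cores in this assay, a 29-fold lower number (1.46 log units; beyond the scatter) from compound 1 to compound 3 and a 2.0-fold higher number (0.30 log units; within the scatter) from compound 2 to compound 4, 57-fold (1.76 log units) apart, beyond the scatter of two such steps. The new step, a 2.0-fold higher number from compound 2 to compound 4 (0.30 log units; within the scatter), gives no sign of a gain on the core of compound 2, where the entering group sits next to the ring atom that bears a methyl group and no ring nitrogen keeps its hydrogen. This does not show why the two steps part, as they differ both in the core and in which ring nitrogen takes the group, and these four compounds cannot separate the two, so neither can be held responsible on its own.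

Open, as far as these compounds go, is whether methoxycarbonyl on the nitrogen next to the ring atom that bears a methyl group would give a step of the size seen for compound 3 or of the size seen for compound 4 if it were set on the core of compound 1. Also open, from the compounds shown here alone, is how a longer chain such as ethoxycarbonyl, or an acetyl group, would read on either ring nitrogen of these cores.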